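Amide substituent swap: from ethyl to a dimethylphenyl group

The compounds below may be only part of what the source reports. "The series", "measured", "known", "first", "only" and "open" are said of these compounds alone.

Three compounds share a core and differ only at the carbonyl carbon or the amide nitrogen. In a functional assay on the whole organism (Ear) for inhibition, with Mus musculus as the target, at a dose of 40 mg/kg by the oral route (a lower number here means less inhibition, a higher number more inhibition at the dose given (going by the name of the read-out)), compound 1 `CC(=O)Oc1ccc(-c2ccc(F)cc2F)cc1C(=O)O` gives 13.7%, compound 2 `CCNC(=O)c1cc(-c2ccc(F)cc2F)ccc1OC(C)=O` gives 5.38%, and compound 3 `CC(=O)Oc1ccc(-c2ccc(F)cc2F)cc1C(=O)NC1CCCCC1` gives 0%. Compound 2 stands second highest of the three, within the scatter of both neighbours. Compound 4 `CC(=O)Oc1ccc(-c2ccc(F)cc2F)cc1C(=O)Nc1cc(C)ccc1C` differs from compound 2 by 2,5-dimethylphenyl in place of ethyl on an amide-type nitrogen. Within the data shown here, the nearest precedent is the change on the same nitrogen, a number 5.4 percentage points lower from compound 2 to compound 3 (within the scatter), which stayed within the scatter; nothing else tests an aromatic group there. A small step, if any, is therefore expected: a number 2.4 percentage points lower from compound 2 to compound 4 (within the scatter). Compound 4 is estimated at 3%, in the range 0% to 14%.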

Compound 4, a percentage reported as inhibition, in the whole organism at one dose (the size of the read-out at that dose, not a potency): 22%
The estimate for compound 4 lay 19 percentage points below the measured number; measured number outside the range, above it.
By their numbers in this assay, from the lowest: compounds 3, 2, 1 and 4 (each within the scatter of the next, the first and the last beyond it).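

Putting 2,5-dimethylphenyl on the amide nitrogen gives a number 16.6 percentage points higher from compound 2 to compound 4 (beyond the scatter) and a number 22 percentage points higher from compound 3 to compound 4 (beyond the scatter) in this assay, so this nitrogen does respond to its substituent once an aromatic ring sits there. Against the free acid the same amide brings no clear gain, with a number 8.3 percentage points higher from compound 1 to compound 4 (within the scatter) for (2,5-dimethylphenyl)amino in place of hydroxy on the carbonyl carbon. No evidence at hand explains the rise. An unsubstituted phenyl on the same nitrogen would show whether the ring alone is enough or the two methyl groups also count.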